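Pyridinyloxy in place of trifluoromethyl on the acylguanidine series

The source may report more compounds than this note shows. Statements on the series, on what has been measured and on what is new or still open speak of the compounds shown alone.

Of the compounds shown here, three have been measured in a functional assay for inhibition of sodium/hydrogen exchanger (Oryctolagus cuniculus); a higher number here means a weaker inhibitor, a lower number a stronger inhibitor. Compound 1 `CS(=O)(=O)c1cc(C(=O)N=C(N)N)c(Cl)cc1Oc1cccnc1` gives 52 nM. Compound 2 `CS(=O)(=O)c1cc(C(=O)N=C(N)N)ccc1C#N` gives 140 nM, and compound 3 `CS(=O)(=O)c1cc(C(=O)N=C(N)N)ccc1C(F)(F)F` gives 140 nM. Compound 3 therefore stands level with compound 2, the two together at the high end of the three numbers, with compound 1 the furthest away and the lowest of the set.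

The next compound, compound 4 `CS(=O)(=O)c1cc(C(=O)N=C(N)N)ccc1Oc1cccnc1`, differs from compound 3 in one place: (pyridin-3-yl)oxy in place of trifluoromethyl on an aromatic carbon. For the measured compounds named here, only one measured step touches this position, the change no change at the digits printed from compound 2 to compound 3 (within the scatter), and it exchanges two groups of which neither is the (pyridin-3-yl)oxy group, so it says little about the present change. Going by the values given here, what the numbers do show is that compound 1, which carries the (pyridin-3-yl)oxy group together with a chloro group, sits lower than compound 3, with no single-point step between them recorded. On that basis the expectation is a modest move downward in this assay, a 1.8-fold lower number from compound 3 to compound 4 (0.24 log units; within the scatter), though it may not clear the scatter. For compound 4 the estimate is 80 nM, with a range from 30 nM to 250 nM.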

Compound 4, half-maximal inhibitory concentration: 76 nM
Beside the measured number, compound 4's estimate is 1.1-fold (0.02 log units) above it, and the stated range covers the measured number.
By their numbers in this assay, from the lowest: compounds 1, 4, 2 and 3 (each within the scatter of the next, the first and the last beyond it).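

In this assay this position, ortho to a methylsulfonyl group, accepts a ring-bearing group in place of a small one: the (pyridin-3-yl)oxy group gives a 1.8-fold lower number from compound 3 to compound 4 (0.27 log units; within the scatter) against trifluoromethyl and a 1.8-fold lower number from compound 2 to compound 4 (0.27 log units; within the scatter) against cyano, both steps staying inside the scatter. For the compounds shown here, with the same (pyridin-3-yl)oxy group in place, the chloro group of compound 1 can also be read on its own for the first time, and hydrogen in place of chloro gives a 1.5-fold higher number from compound 1 to compound 4 (0.16 log units; within the scatter), again a step that does not separate the two compounds. Nothing measured alongside these compounds accounts for any of these steps.

Still open, from the compounds shown here alone, is whether an amine, a carboxylic acid or a longer alkoxy chain on this same aromatic carbon would give a step beyond the scatter in this assay, which none of the three groups compared here does. A phenoxy group at this place would show whether the ring nitrogen of the (pyridin-3-yl)oxy group matters at all, and a fluoro or methyl group in place of the chloro group would test that second position further.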